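This account rests on a few compounds, and the source may have more. Where it says the series, first, only, none or still open, it means among the compounds named here.

Measured in a physicochemical assay for solubility, read by HPLC, in phosphate buffer, at pH 6.5; on this read-out lower numbers stand for lower solubility and higher numbers for higher solubility:
- compound 1 `COC(=O)C1=C(C)NC(c2nccs2)=NC1(C)c1ccc(S(C)(=O)=O)cc1`: 365 ug/mL
- compound 2 `COC(=O)C1=C(C)NC(c2nccs2)=NC1(C)c1ccc(F)c(F)c1`: 50 ug/mL
- compound 3 `COC(=O)C1=C(CN2CC3CC2CO3)NC(c2nccs2)=NC1(C)c1ccc(F)cc1`: 564 ug/mL

Compound 3 gives 564 ug/mL, which lies within the usual scatter of compound 1 at 365 ug/mL. Compared with compound 3, compound 2 lies far lower at 50 ug/mL, a gap well beyond the scatter.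

The next compound to be tested is compound 4 `COC(=O)C1=C(CN2CCC(O)C2)NC(c2nccs2)=NC1(C)c1ccc(F)cc1`. It differs from compound 3 in one place: a group of 6 heavy atoms (4 carbon, 1 nitrogen, 1 oxygen; one five-membered non-aromatic ring with 1 hetero atom) in place of a group of 7 heavy atoms (5 carbon, 1 nitrogen, 1 oxygen; 2 five-membered non-aromatic rings with 1 hetero atom each), on a saturated chain carbon bound to a double-bonded ring carbon. The entering group is 3-hydroxypyrrolidin-1-yl, and it sits on a saturated chain carbon bound to a double-bonded ring carbon.

Within the data shown here, no two measured compounds differ in only one place, so the data contain no earlier step to serve as a guide for this change. In this assay, no step beyond the scatter is expected, and neither direction is favoured with any confidence. The expected change is a 1.1-fold higher number from compound 3 to compound 4 (0.03 log units; within the scatter). For compound 4 the estimate is 600 ug/mL, with an expected range of 250 ug/mL to 1200 ug/mL.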

Compound 4, solubility: 503 ug/mL
For compound 4 the middle estimate is 1.2-fold (0.08 log units) above the measured one; the measured number falls inside the stated range.
By their numbers in this assay, from the lowest: compound 2; then compounds 1, 4 and 3 (each within the scatter of the next).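

Among these compounds, this is the first comparison here in which only one place changes: on a saturated chain carbon bound to a double-bonded ring carbon, 3-hydroxypyrrolidin-1-yl replaces the group with 2 five-membered non-aromatic rings. In this assay, this gives a 1.1-fold lower number from compound 3 to compound 4 (0.05 log units; within the scatter), so at this position, the loss of one of those rings and the exchange of a group with 0 hydrogen-bond donors for one with 1 hydrogen-bond donor leave the read-out within the usual scatter. No measurement is available to explain this result.

From the compounds shown here alone, it remains open whether a dimethylamino group or a carboxylic acid at this same place would also stay within the scatter. Compounds 1 and 2 differ from compound 3 in more than one place, so they cannot show what the groups at this position contribute on their own.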